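A Lone Number Before an Aryl Exchange

The source may report more compounds than this note shows. Statements on the series, on what has been measured and on what is new or still open speak of the compounds shown alone.

In a functional assay on HeLa cells (Homo sapiens) for antiproliferative activity, read by MTT assay, with a stated time of 72 h (a lower number here means a stronger inhibitor, a higher number a weaker inhibitor), compound 1 (`CCNC(=O)c1cc(Oc2ccc(NC(=O)c3nn(-c4ccc(Br)cc4F)c(=O)cc3C)cc2)ccn1`) is reported as "not active" (no number reported), with no number given. Going by the values given here, compound 2 (`CCCNC(=O)c1cc(Oc2ccc(NC(=O)c3nn(-c4ccc(Br)cc4F)c(=O)cc3C)cc2F)ccn1`) gives 53500 nM, the only number available in this small set. Compound 3 (`CCCNC(=O)c1cc(Oc2ccc(NC(=O)c3nn(-c4ccccc4OC(F)(F)F)c(=O)cc3C)cc2F)ccn1`) carries 2-(trifluoromethoxy)phenyl in place of 4-bromo-2-fluorophenyl on an aromatic nitrogen. Among the compounds with values here, no measured step bears on this exchange, so no change beyond the usual scatter is expected in this assay. The expected step is a 1.3-fold lower number from compound 2 to compound 3 (0.13 log units; within the scatter). The estimated value for compound 3 is 40000 nM, with an expected range from 12000 nM to 120000 nM.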

Compound 3, half-maximal inhibitory concentration: 3690 nM
Compound 3: middle estimate off by 11-fold (1.04 log units), on the high side; measured number outside the range, below it.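

In this assay, the group on the aromatic nitrogen proves able to move the result: 2-(trifluoromethoxy)phenyl in place of 4-bromo-2-fluorophenyl gives a 14-fold lower number from compound 2 to compound 3 (1.16 log units; beyond the scatter). The exchange replaces a group with one of more heavy atoms and brings in 1 hydrogen-bond acceptor, so several things change at once. No measurement shown here explains the step. The compounds shown leave open how a plain phenyl or a 2-methoxyphenyl group on that nitrogen would compare with compound 3.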